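Removing One Methyl from the Fluorophenyl Ring of Compound 2

The compounds below may be only part of what the source reports. "The series", "measured", "known", "first", "only" and "open" are said of these compounds alone.

Values measured in a functional assay on SW-620 cells (Homo sapiens) for cytotoxicity; on this read-out higher numbers stand for weaker inhibition of growth and lower numbers for stronger inhibition of growth:
- Compound 1 `COc1ccc(C2=C(c3ccc(SC)cc3)CC3CCCN3C2=O)cc1OC(=O)CNC(=O)OC(C)(C)C`: 20000 nM
- Compound 2 `CSc1ccc(C2=C(c3ccc(F)c(C)c3)C(=O)N3CCCC3C2)cc1`: 600 nM
- Compound 3 `COc1ccc(C2=C(c3ccc(SC)cc3)CC3CCCN3C2=O)cc1OC`: 3000 nM

Compound 2 has the lowest of the three numbers at 600 nM, and its gaps to the other two lie beyond the scatter. The next compound in the series, compound 4 `CSc1ccc(C2=C(c3ccc(F)cc3)C(=O)N3CCCC3C2)cc1`, has not yet been measured. It differs from compound 2 by one small change: hydrogen in place of methyl on an aromatic carbon. This is hydrogen in place of methyl on an aromatic carbon, turning 4-fluoro-3-methylphenyl into 4-fluorophenyl.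

Going by the values given here, only one measured step exists, a 6.7-fold lower number from compound 1 to compound 3 (0.82 log units; beyond the scatter). It exchanges a much larger group on an oxygen for methyl, elsewhere in the molecule, so it offers only a loose sense of scale. Among the compounds with values here, no measured pair isolates this methyl, and the data therefore support no firm direction in this assay. The estimate is a small move, a 1.3-fold higher number from compound 2 to compound 4 (0.12 log units; within the scatter), which is expected to stay within the scatter. For compound 4 the expected value is 800 nM, with an estimated range from 250 nM to 2500 nM.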

Compound 4, concentration for 50% growth inhibition: 500 nM
The estimate for compound 4 lay 1.6-fold (0.20 log units) above the measured number; the range from low to high includes it.
By their numbers in this assay, from the lowest: compounds 4 and 2 (each within the scatter of the next); then compound 3; then compound 1.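

Going by these compounds alone, the step of a 1.2-fold lower number from compound 2 to compound 4 (0.08 log units; within the scatter) in this assay gives the first measured reading at this position: the methyl on the aromatic carbon ortho to the fluoro group can give way to hydrogen with no change beyond the scatter. For this pair, then, the read-out does not depend on that methyl, and 4-fluorophenyl serves as well as 4-fluoro-3-methylphenyl. No supporting measurement is available to explain this result.

On these data alone, since only hydrogen and methyl are compared at this carbon, it remains open whether a larger or different group there, such as an ethyl, a methoxy or an amine, would move the number beyond the scatter. Within the data shown here, it is also open whether the fluoro group matters, as no compound here carries a chlorine or a hydrogen in its place.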